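Cyclobutylmethoxy in Place of Isopropylamino on a Shared Core

This account rests on a few compounds, and the source may have more. Where it says the series, first, only, none or still open, it means among the compounds named here.

Compound 1 `CC1=C(C(N)=O)C(c2ccoc2)NC(=O)N1` and compound 2 `CC1=C(C(=O)NC(C)C)C(c2ccoc2)NC(=O)N1` share one core and differ only in the group on the amide-type nitrogen. In an assay on membranes from HeLa cells for displacement of a labelled ligand from adenosine receptor A3 (Homo sapiens), read by scintillation counting, with a stated time of 180 min, tested at 1 uM (on this read-out lower numbers stand for less inhibition and higher numbers for more inhibition at the one concentration tested (going by the name of the read-out)), compound 1 gives 2%, and compound 2 gives 3%. Among the compounds with values here, the single measured step, a number 1 percentage points higher from compound 1 to compound 2 (within the scatter), is within the scatter, so the two compounds cannot be told apart; by count alone compound 2 holds the higher of the two numbers, with compound 1 nearest at a gap within the scatter.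

Compound 3 `CC1=C(C(=O)OCC2CCC2)C(c2ccoc2)NC(=O)N1` has not been measured. Compared with compound 2, the change is cyclobutylmethoxy in place of isopropylamino on a carbonyl carbon. Within the data shown here, only one measured step touches this part of the molecule, and it altered just what sits on the amide-type nitrogen, whereas here the whole isopropylamino group gives way to cyclobutylmethoxy. That step was within the scatter, and both measured numbers sit near the bottom of the scale, so the expected step is none beyond the scatter, a number 1 percentage points higher from compound 2 to compound 3 (within the scatter). Compound 3 is therefore estimated at 4%, expected to fall between -8% and 20%.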

Compound 3, a percentage reported as inhibition, at one concentration (the size of the read-out at that concentration, not a potency): 2%
Compound 3: middle estimate off by 2 percentage points, on the high side, within the range that was stated.
By their numbers in this assay, from the lowest: compounds 1, 3 and 2 (each within the scatter of the next).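

Up to this point, only the group on the amide-type nitrogen had changed; now the atom attached to the carbonyl carbon changes too, and in this assay the step for cyclobutylmethoxy in place of isopropylamino is a number 1 percentage points lower from compound 2 to compound 3 (within the scatter) and stays small. The comparison with the unsubstituted amide gives no change at the digits printed from compound 1 to compound 3 (within the scatter) for cyclobutylmethoxy in place of amino, so amino, isopropylamino and cyclobutylmethoxy cannot be told apart on this carbonyl carbon, even though the last swap exchanges a group counted with a hydrogen-bond donor for one with a four-membered ring and a hydrogen-bond acceptor. No supporting data bear on why these three numbers cannot be separated.

All three numbers sit near the bottom of the scale at the single concentration tested, so the compounds shown cannot tell whether any group on this carbonyl carbon can produce a clear rise in inhibition. On these data alone, how a carboxylic acid, a benzylamino group or a longer alkoxy chain would read at this place remains open.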